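The source may hold more compounds than are shown below. What is called first, only, known or untested is meant among the compounds shown, and "the series" means these compounds.

Compound 1 (`O=C(Cn1nc(Cc2ccccc2)c2ccccc2c1=O)Nc1ccccc1`) gives 95400 nM in a functional assay on HT-29 cells (Homo sapiens) for antiproliferative activity, read by sulforhodamine B assay, with a stated time of 72 h; a lower number here means a stronger inhibitor, a higher number a weaker inhibitor. Compound 2 (`COc1ccc(NC(=O)Cn2nc(Cc3ccccc3)c3ccccc3c2=O)cc1`) reads > 100000000 nM, which is a limit of the assay and not a number. Compound 3 (`O=C(Cn1nc(Cc2ccccc2)c2ccccc2c1=O)Nc1ccccc1Cl`) differs from compound 2 as follows: 2-chlorophenyl in place of 4-methoxyphenyl on an amide-type nitrogen. Among the measured compounds shown here, the only measured step bearing on this is an at least 1000-fold higher number from compound 1 to compound 2 (3.02 log units; beyond the scatter), and compound 3 carries no methoxy. The effect of 2-chlorophenyl has not been measured. A large move to a lower number is therefore expected in this assay, and the estimated step is an at least 1600-fold lower number from compound 2 to compound 3 (3.22 log units; beyond the scatter). For compound 3 the expected value is 60000 nM, with an estimated range of 10000 nM to 400000 nM.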

Compound 3, half-maximal inhibitory concentration: 42800 nM
The estimate for compound 3 lay 1.4-fold (0.15 log units) above the measured number; low and high end bracket the measured number.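

On the amide-type nitrogen in this assay, a substituted phenyl need not abolish activity: 2-chlorophenyl in place of 4-methoxyphenyl gives an at least 2300-fold lower number from compound 2 to compound 3 (3.36 log units; beyond the scatter). For compound 2 the reading is a limit of the assay and not a number: the limit of > 100000000 nM in this assay, at which 1 of the 3 values shown sits. Relative to the unsubstituted phenyl, chloro in place of hydrogen gives a 2.2-fold lower number from compound 1 to compound 3 (0.35 log units; beyond the scatter), so chloro is the only substituent shown that leads to a lower number.

The step from 4-methoxyphenyl to 2-chlorophenyl changes both the group and its place on the ring, and the compounds shown do not separate the two. From the compounds shown here alone, how 2-methoxyphenyl, 4-chlorophenyl or a phenyl bearing a carboxylic acid would read remains open.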